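The source may report more compounds than this note shows. Statements on the series, on what has been measured and on what is new or still open speak of the compounds shown alone.

Measured in a functional assay on HeLa cells (Homo sapiens) for cytotoxicity, read by MTT assay, in the presence of a further agent that is not named here; on this read-out lower numbers stand for stronger inhibition and higher numbers for weaker inhibition:

- Compound 1 `CC(C)(C)[Si](C)(C)O[C@@H]1[C@H](O[Si](C)(C)C(C)(C)C)[C@@H](C2CC(=O)S[S+]2[O-])O[C@H]1n1ccc(=O)[nH]c1=O`: 2670 nM
- Compound 2 `O=C1CC([C@H]2O[C@@H](n3ccc(=O)[nH]c3=O)[C@H](O)[C@@H]2O)SS1`: 20700 nM

Of these two numbers, compound 2 stands highest at 20700 nM, which marks it as the weaker inhibitor. The gap down to compound 1 lies beyond the usual scatter.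

Compound 3 `O=C1CC([C@H]2O[C@@H](n3ccc(=O)[nH]c3=O)[C@H](O)[C@@H]2O)[S+]([O-])S1` has not yet been measured. It differs from compound 2 at one place, on a saturated ring carbon of a five-membered non-aromatic ring with 1 oxygen: a group of 7 heavy atoms (3 carbon, 2 oxygen, 2 sulfur; one five-membered non-aromatic ring with 2 hetero atoms) in place of a group of 6 heavy atoms (3 carbon, 1 oxygen, 2 sulfur; one five-membered non-aromatic ring with 2 hetero atoms), on a saturated ring carbon.

Going by the values given here, no measured pair shows this change alone, so any forecast rests on thin evidence. The lower number of compound 1, at 2670 nM, points to a moderate shift towards stronger inhibition. The expected change is a 2.3-fold lower number from compound 2 to compound 3 (0.36 log units; beyond the scatter), though a step within the scatter remains possible. For compound 3 the estimated value is 9000 nM, with an expected range from 2500 nM to 30000 nM.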

Compound 3, half-maximal inhibitory concentration: 7010 nM
Estimate against measurement, compound 3: 1.3-fold (0.11 log units) above, and the stated range covers the measured number.
By their numbers in this assay, from the lowest: compound 1; then compound 3; then compound 2.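

In this assay, going by these compounds alone, the pair of compound 2 and compound 3 isolates a single change for the first time. A group of 7 heavy atoms (3 carbon, 2 oxygen, 2 sulfur) takes the place of a group of 6 heavy atoms (3 carbon, 1 oxygen, 2 sulfur) on the saturated ring carbon next to the ring oxygen, and this gives a 3.0-fold lower number from compound 2 to compound 3 (0.47 log units; beyond the scatter). The one extra oxygen in this group is therefore enough on its own to shift the number modestly towards stronger inhibition on the shared core. Nothing given here explains this shift.

From the compounds shown here alone, this rests on a single pair, so it remains open whether the shift would hold on other cores. Also open, going by these compounds, is how a sulfone in the five-membered ring with 2 hetero atoms, or an amine or a carboxylic acid in place of the whole group, would behave at this position.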